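Chromone acrylamides: swapping an aromatic chloro for methoxy

The source may hold more compounds than are shown below. What is called first, only, known or untested is meant among the compounds shown, and "the series" means these compounds.

Measured compounds:
compound 1, `COc1ccc2c(=O)c(/C=C/C(=O)Nc3ccccc3Cl)coc2c1`, 29900 nM in a functional assay on A549 cells (Homo sapiens) for inhibition, read by MTT assay, with a stated time of 48 h; a lower number here means a stronger inhibitor, a higher number a weaker inhibitor
compound 2, `O=C(/C=C/c1coc2cc(O)ccc2c1=O)NCc1ccc(F)cc1`, > 100000 nM in this assay

Among the measured compounds shown here, compound 1 stands as the only compound of this pair that gives a number in this assay, and that number is a weak one. For compound 2 the result is a limit of the assay rather than a number, as the report of > 100000 nM shows; this is the limit of > 100000 nM in this assay, at which 1 of the 2 values shown sits. For the measured compounds named here, because no pair of measured compounds differs in a single place, no measured step exists, and the two values say only that compound 1 gives a number while compound 2 does not.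

Compound 3, `COc1ccc2c(=O)c(/C=C/C(=O)Nc3ccccc3OC)coc2c1`, differs from compound 1 in one place: methoxy in place of chloro on an aromatic carbon. Going by the values given here, nothing among the measured compounds shows what such a change does in this assay, so the expected step from a 1.2-fold higher number from compound 1 to compound 3 (0.07 log units; within the scatter) is none beyond the usual scatter, with the direction left open. Compound 3 is therefore estimated at 35000 nM in this assay, with a range from 12000 nM to 100000 nM, and a real chance that only a limit is reported.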

Compound 3, half-maximal inhibitory concentration: > 100000 nM
Compound 3 ended at the assay's limit; the forecaster's own chance of this, stated with the estimate: 25%; middle value at least 2.8-fold (0.45 log units) away from the limit.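

Among the compounds shown, this is the only measured step, and it falls on an aromatic carbon ortho to a large group: in this assay, the change from 2-chlorophenyl to 2-methoxyphenyl gives an at least 3.3-fold higher number from compound 1 to compound 3 (0.52 log units; beyond the scatter). Compound 3 gives > 100000 nM, which is a limit of the assay and not a number. With the core of compound 1 held fixed, the earlier compounds could not show that this one place matters in this read-out, yet the size of the step can only be read as a minimum, because the higher end of it rests on a limit rather than a number: the limit of > 100000 nM in this assay, at which 2 of the 3 values shown sit.

The compounds shown leave open how far compound 3 lies past that limit, and whether the change reflects methoxy in particular or holds for other replacements of chloro at this place. From the compounds shown here alone, whether a fluoro, a methyl or an amine on this aromatic carbon would keep a measurable number like that of compound 1, and what chloro would do on another carbon of the same ring, also stays open.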